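Swapping a dimethylamino for chloro on the hydrazone aryl ring

The source may report more compounds than this note shows. Statements on the series, on what has been measured and on what is new or still open speak of the compounds shown alone.

Measured so far:
- compound 1 `O=C(N/N=C/c1ccc(Cl)cc1Cl)Nc1cccc2ccccc12`: 100 mg/kg
- compound 2 `O=C(N/N=C/c1ccc(F)cc1)Nc1cccc2ccccc12`: 300 mg/kg
- compound 3 `CN(C)c1ccc(/C=N/NC(=O)Nc2cccc3ccccc23)cc1`: 100 mg/kg

All three compounds were tested in a functional assay on the whole organism (strain Swiss albino) with Mus musculus as the target, in the maximal electroshock model, with a stated time of 4 h; a higher number here means that more compound is needed for the effect, a lower number that less compound is needed. Compound 3 stands level with compound 1 at the digits given, and together these two give the lowest numbers of the three; compound 2 sits apart, higher than compound 3 by a 3.0-fold lower number from compound 2 to compound 3 (0.48 log units; beyond the scatter) read in reverse.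

Compound 4 `O=C(N/N=C/c1ccc(Cl)cc1)Nc1cccc2ccccc12` has not yet been measured in this assay. It differs from compound 3 by chloro in place of dimethylamino on an aromatic carbon, the change sitting on an aromatic carbon para to a large group. For the measured compounds named here, two measured steps bear on it. The step of a 3.0-fold lower number from compound 2 to compound 3 (0.48 log units; beyond the scatter) shows that putting dimethylamino where a halogen stood lowered the number, so taking it away again and putting in a halogen may be expected to raise it. The step of a 3.0-fold higher number from compound 1 to compound 2 (0.48 log units; beyond the scatter) shows that a chlorine-bearing ring gave a lower number than a fluorine-bearing one. A moderate rise is therefore expected for compound 4, of about a 2.0-fold higher number from compound 3 to compound 4 (0.30 log units; within the scatter). The estimate for compound 4 is 200 mg/kg, within a range from 100 mg/kg to 400 mg/kg.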

Compound 4, minimum effective dose: 300 mg/kg
Compound 4: the middle estimate sits 1.5-fold (0.18 log units) below what was measured; the range from low to high includes it.
By their numbers in this assay, from the lowest: compounds 1 and 3 (each within the scatter of the next); then compounds 2 and 4 (each within the scatter of the next).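

In this assay, chloro in place of dimethylamino on this aromatic carbon gives a 3.0-fold higher number from compound 3 to compound 4 (0.48 log units; beyond the scatter), so a direct swap now confirms that the lower number goes with dimethylamino rather than with a halogen in general. The two halogens cannot be told apart at this position, with chloro in place of fluoro giving no change at the digits printed from compound 2 to compound 4 (within the scatter). Hydrogen in place of the other chloro gives a 3.0-fold higher number from compound 1 to compound 4 (0.48 log units; beyond the scatter), which shows that the second chloro also matters and that the earlier gap between the dichloro and fluoro compounds need not reflect the fluoro at all.

Nothing available explains why these groups differ in this assay. As far as these compounds go, whether a simple amine or a methoxy group on this aromatic carbon would match dimethylamino remains open.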